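The source may hold more compounds than are shown below. What is called first, only, known or untested is meant among the compounds shown, and "the series" means these compounds.

In a functional assay on A549 cells (Homo sapiens) for cytotoxicity, read by MTT assay, with a stated time of 72 h (on this read-out lower numbers stand for stronger inhibition and higher numbers for weaker inhibition), compound 1 `COc1ccccc1/C=C1\CCC/C(=C\c2cccc(OC)c2OC)C1=O` gives only a limit, > 20000 nM. Within the data shown here, compound 2 `COc1cccc(/C=C2\CCC/C(=C\c3cccc(OC)c3OC)C2=O)c1` gives 16400 nM in this assay, the only number among the three measured; the cores of compound 1 and compound 2 differ by 3-methoxyphenyl in place of 2-methoxyphenyl on a double-bonded chain carbon bound to a double-bonded ring carbon, a step of an at least 1.2-fold lower number from compound 1 to compound 2 (0.08 log units; that floor lies within the scatter). Compound 3 `COc1ccc(/C=C2\CCC/C(=C\c3cccc(OC)c3OC)C2=O)c(OC)c1` likewise gives only a limit, > 20000 nM. The change here is methoxy in place of hydrogen on an aromatic carbon, and its step is a step that the two limits leave unreadable from compound 1 to compound 3 because the limit of > 20000 nM in this assay, at which 2 of the 3 values shown sit, caps both ends. Compound 4 `COc1cc(/C=C2\CCC/C(=C\c3cccc(OC)c3OC)C2=O)cc(OC)c1` carries the same kind of change from compound 2, (methoxy in place of hydrogen on an aromatic carbon), but its place is meta to a large group rather than para to a large group. Given compound 2 at 16400 nM and the unreadable step that the two limits leave unreadable from compound 1 to compound 3, the step to compound 4 is expected to be about a 1.2-fold higher number from compound 2 to compound 4 (0.09 log units; within the scatter). Compound 4 is therefore estimated at 20000 nM in this assay, between 9000 nM and 45000 nM.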

Compound 4, half-maximal inhibitory concentration: 10200 nM
For compound 4 the middle estimate is 2.0-fold (0.29 log units) above the measured one; measured number inside the range.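

In this assay, methoxy in place of hydrogen on an aromatic carbon, meta to a large group, gives a 1.6-fold lower number from compound 2 to compound 4 (0.21 log units; within the scatter), so on the core of compound 2 this change leaves the two values within the scatter of each other. The same kind of change on the core of compound 1 cannot be read because both ends of that step, compound 1 and compound 3, are limits and not numbers: the limit of > 20000 nM in this assay, at which 2 of the 4 values shown sit. The series therefore shows one readable instance of the change and does not show whether its outcome carries from one core to another.

The compounds shown leave open how an amine or a carboxylic acid in place of a methoxy group on these aromatic rings would read in this assay.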